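The source may report more compounds than this note shows. Statements on the series, on what has been measured and on what is new or still open speak of the compounds shown alone.

Measured compounds:
Compound 1 `COc1ccc(-c2c(C#N)c(-c3ccccc3)nc3c2c(-c2ccccc2)nn3-c2ccccc2)cc1OC` — > 25000 nM
Compound 2 `Cc1ccc(-c2nc3c(c(-c4ccccc4)nn3-c3ccccc3)c(-c3ccc(O)cc3)c2C#N)cc1` — 8800 nM

Both were tested in a functional assay on K562 cells (Homo sapiens) for antiproliferative activity, read by resazurin assay, with a stated time of 72 h; a lower number here means a stronger inhibitor, a higher number a weaker inhibitor. For compound 1 this assay reports only a limit, > 25000 nM, not a number (the limit of > 25000 nM in this assay, at which 1 of the 2 values shown sits). For the measured compounds named here, compound 2 gives 8800 nM in this assay, and this is the single real number available, so there is no measured step to lean on.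

Compound 3 `N#Cc1c(-c2cccs2)nc2c(c(-c3ccccc3)nn2-c2ccccc2)c1-c1ccc(O)cc1` has not yet been measured. It differs from compound 2 in one place: thiophen-2-yl in place of 4-methylphenyl on an aromatic carbon. The leaving group is a six-membered aromatic ring of carbon only; the entering thiophen-2-yl is a five-membered aromatic ring with 1 hetero atom and brings 1 hydrogen-bond acceptor. Going by the values given here, no measured pair shows what such a swap does here, so the expectation rests on compound 2 and its value of 8800 nM. I expect the step of a 1.3-fold lower number from compound 2 to compound 3 (0.10 log units; within the scatter) to stay within the usual scatter, with no clear direction. My estimate for compound 3 in this assay is 7000 nM, between 2500 nM and 20000 nM.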

Compound 3, half-maximal inhibitory concentration: 11600 nM
Beside the measured number, compound 3's estimate is 1.7-fold (0.22 log units) below it, and the stated range covers the measured number.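

In this assay, putting thiophen-2-yl in place of 4-methylphenyl on the aromatic carbon next to the ring nitrogen gives a 1.3-fold higher number from compound 2 to compound 3 (0.12 log units; within the scatter). For the compounds shown here, this is the first measured comparison of compounds that differ in only one place, and it shows that, for this pair, a five-membered aromatic ring with a sulfur atom can stand in for a six-membered aromatic ring of carbon only with no difference beyond the usual scatter. None of the available evidence bears on why these two groups give such similar results.

The compounds shown leave open whether this position would give a similar result with a group lacking an aromatic ring, such as an amine or a carboxylic acid. They also leave open what would happen if the 4-hydroxyphenyl group shared by compound 2 and compound 3 were replaced by 4-aminophenyl.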